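Directly attached aryl versus benzyl and microsomal stability

This account rests on a few compounds, and the source may have more. Where it says the series, first, only, none or still open, it means among the compounds named here.

Measured so far:
compound 1 `C[C@H](c1ccccc1)N1C(=O)O[C@](Cc2ccccc2)(c2nnc(-c3ccc(Cl)c(Cl)c3)[nH]2)C1=O` gives 88% in an ADME assay (liver) for metabolic stability, with Liver microsome (Homo sapiens) as the target, using microsomes, with a stated time of 0.5 h, tested at 1 uM; on this read-out lower numbers stand for a less stable compound and higher numbers for a more stable compound
compound 2 `C[C@H](c1ccccc1)N1C(=O)O[C@](Cc2ccccc2)(c2nnc(-c3ccccc3)o2)C1=O` gives 82% in this assay
compound 3 `C[C@H](c1ccccc1)N1C(=O)O[C@](Cc2ccccc2)(c2nnc(Cc3ccccc3)o2)C1=O` gives 7% in this assay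

Compound 3 stands lowest of the three; compound 2 is nearest and compound 1 furthest, both beyond the scatter. Compound 4 `C[C@H](c1ccccc1)N1C(=O)O[C@](Cc2ccccc2)(c2nnc(-c3cc(F)cc(F)c3)o2)C1=O` differs from compound 3 by 3,5-difluorophenyl in place of benzyl on an aromatic carbon. For the measured compounds named here, the one measured step at this position is a number 75 percentage points lower from compound 2 to compound 3 (beyond the scatter), which compound 4 reverses, apart from the two fluorines, for which no step exists; compound 1 differs in another ring and does not bear on it. A large upward step is therefore expected, a number 71 percentage points higher from compound 3 to compound 4 (beyond the scatter). Compound 4 is estimated at 78%, in the range 55% to 95%.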

Compound 4, percent of the compound remaining: 74%
Beside the measured number, compound 4's estimate is 4 percentage points above it; measured number inside the range.
By their numbers in this assay, from the lowest: compound 3; then compounds 4, 2 and 1 (each within the scatter of the next, the first and the last beyond it).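

At this position, 3,5-difluorophenyl gives a number 67 percentage points higher from compound 3 to compound 4 (beyond the scatter) in this assay and so restores a high number with a second directly attached aryl group, leaving benzyl as the only low case among the groups shown here. Against phenyl there is a number 8 percentage points lower from compound 2 to compound 4 (within the scatter) and the two fluorines therefore leave no readable difference. Nothing available explains the gap between benzyl and the directly attached aryl groups.

Still open, from the compounds shown here alone, is whether an amine or a methoxy group on the phenyl ring would hold the number. Also open, going by these compounds, is how a longer chain in place of benzyl would read, and whether the benzyl result carries over to the core of compound 1.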